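This account rests on a few compounds, and the source may have more. Where it says the series, first, only, none or still open, it means among the compounds named here.

Compound 2 (`O=[N+]([O-])c1ccc(NC(CO)CO)c([N+](=O)[O-])c1`) is one of two measured compounds built on the same amino-diol core. In an ADME assay on MRC5 cells (Homo sapiens) for cytotoxicity (on this read-out lower numbers stand for stronger inhibition and higher numbers for weaker inhibition), compound 2 gives only a limit of the assay, > 100000 nM. Compound 1 (`O=[N+]([O-])c1ccccc1NC(CO)CO`) lacks one nitro group; in this assay compound 1 likewise gives only a limit, > 100000 nM. The step that the two limits leave unreadable from compound 1 to compound 2 therefore has no readable size, because the limit of > 100000 nM in this assay, at which 2 of the 2 values shown sit, means both ends of that step are open.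

Compound 3 (`O=[N+]([O-])c1cc(C(F)(F)F)ccc1NC(CO)CO`) has not yet been measured. It differs from compound 2 by trifluoromethyl in place of nitro on an aromatic carbon. Within the data shown here, no measured step touches this particular exchange, and the single step known here is itself unreadable. With both neighbours sitting at the limit, the expectation is that the step that the limit leaves unreadable from compound 2 to compound 3 stays within the usual scatter, and compound 3 is estimated at 150000 nM, with a range from 30000 nM to 600000 nM, most likely again reported only as a limit.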

Compound 3, half-maximal inhibitory concentration: > 100000 nM
Compound 3: only a limit was reported; the forecaster's own chance of this, stated with the estimate: 80%; the middle value does not contradict the limit.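

No new step can be read, since compound 1, compound 2 and compound 3 all sit at the same limit: the limit of > 100000 nM in this assay, at which 3 of the 3 values shown sit.

The compounds shown leave open how hydrogen, nitro and trifluoromethyl truly compare on the shared core in this assay, and what change, if any, would give a measurable value.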